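Methyl on the Amide Nitrogen and Aortic Potency

The source may report more compounds than this note shows. Statements on the series, on what has been measured and on what is new or still open speak of the compounds shown alone.

In a functional assay on thoracic aorta (Rattus norvegicus, strain Wistar), with a stated time of 15 min (a lower number here means that less compound is needed, a higher number that more compound is needed for the effect), compound 1 `COc1ccc(OC)c(CNC(=O)NS(=O)(=O)c2ccc(Cl)cc2)c1` gives only a limit, > 300000 nM. Compound 3 `CCOc1ccc(Cl)cc1C(C)NC(=O)NS(=O)(=O)c1ccccc1` likewise gives only a limit, > 300000 nM. Compound 2 `CCOc1ccc(Cl)cc1C(C)NC(=O)N(C)S(=O)(=O)c1ccccc1` gives 10500 nM.

Going by the values given here, compound 2 is compound 3 with methyl in place of hydrogen on an amide-type nitrogen; the single measured step is an at least 28-fold lower number from compound 3 to compound 2 (1.45 log units; beyond the scatter). Because compound 3 sits at the limit of > 300000 nM in this assay, at which 2 of the 3 values shown sit, the true size of that step is known only as a lower bound. The difference between the cores of compound 1 and compound 3 is not broken down here. Compound 4 `COc1ccc(OC)c(CNC(=O)N(C)S(=O)(=O)c2ccc(Cl)cc2)c1` is compound 1 with the same change, (methyl in place of hydrogen on an amide-type nitrogen). A gain of similar size is expected for compound 4, an at least 15-fold lower number from compound 1 to compound 4 (1.17 log units; beyond the scatter), resting on an at least 28-fold lower number from compound 3 to compound 2 (1.45 log units; beyond the scatter). Compound 4 is therefore estimated at 20000 nM in this assay. Its expected range for compound 4 runs from 5000 nM to 150000 nM.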

Compound 4, half-maximal effective concentration: 18200 nM
Compound 4: middle estimate off by 1.1-fold (0.04 log units), on the high side; the measured number falls inside the stated range.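

In this assay the new step is an at least 16-fold lower number from compound 1 to compound 4 (1.21 log units; beyond the scatter) and it comes from methyl in place of hydrogen on an amide-type nitrogen, the same change as before but on a different core. On both cores shown, the change therefore turns a compound that reaches only a limit into one with a measured value, so it carries over within this small set. What this does not show is whether the size of the gain is the same on the two cores: the same change on two cores in this assay, an at least 28-fold lower number (1.45 log units; beyond the scatter) from compound 3 to compound 2 and an at least 16-fold lower number (1.21 log units; beyond the scatter) from compound 1 to compound 4; the limit leaves it open whether they differ

The compounds shown leave open whether only methyl does this, or whether an ethyl group or a longer chain in the same place would do the same. Equally open, as far as these compounds go, is how the change behaves on a core carrying a carboxylic acid or an amine.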